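Replacing a Thiophene Amide with a Naphthalene Amide

The compounds below may be only part of what the source reports. "The series", "measured", "known", "first", "only" and "open" are said of these compounds alone.

Of the compounds shown here, three built on a shared core have been measured in a functional assay on A2780 cells (Homo sapiens) for antiproliferative activity, read by fluorescence, with a stated time of 72 h; on this read-out lower numbers stand for stronger inhibition and higher numbers for weaker inhibition. Compound 1 `CN1CCC(C(=O)Nc2n[nH]c3c2CN(C(=O)C(C)(C)C)C3(C)C)CC1` gives 350 nM in this assay. Compound 3 `CN1CCN(C(=O)N2Cc3c(NC(=O)c4ccc(F)cc4)n[nH]c3C2(C)C)CC1` gives 180 nM. Compound 2 `CN1CCC(C(=O)N2Cc3c(NC(=O)c4cccs4)n[nH]c3C2(C)C)CC1` gives 30 nM, the lowest of the three numbers; the nearest is compound 3, whose number is higher by a margin beyond the scatter, and compound 1 lies further away, also beyond the scatter. Compound 2 is therefore the most potent of the three on this read-out.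

Compound 4 `CN1CCC(C(=O)N2Cc3c(NC(=O)c4ccc5ccccc5c4)n[nH]c3C2(C)C)CC1` has not yet been measured in this assay. It differs from compound 2 in one place: naphthalen-2-yl in place of thiophen-2-yl on a carbonyl carbon. Among the compounds with values here, no two measured compounds differ in a single place, so no directly comparable step is available. Both aromatic amides, compound 2 and compound 3, sit below compound 1, but compound 3 also carries a different group on the core nitrogen, so the two aryl amides cannot be set side by side cleanly.

The step expected from compound 2 to compound 4 is a modest weakening, a 2.0-fold higher number from compound 2 to compound 4 (0.30 log units; within the scatter), within or only slightly beyond the scatter. Compound 4 is expected to give 60 nM in this assay, with a likely range from 15 nM to 250 nM.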

Compound 4, half-maximal inhibitory concentration: 270 nM
Estimate against measurement, compound 4: 4.5-fold (0.65 log units) below; measured number above the stated range.
By their numbers in this assay, from the lowest: compound 2; then compounds 3, 4 and 1 (each within the scatter of the next).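

Within the data shown here, the first step in the set that changes a single place is in this assay and gives a 9.0-fold higher number from compound 2 to compound 4 (0.95 log units; beyond the scatter). It shows that the aryl group on this carbonyl carbon, whose other neighbour is the amide-type nitrogen, is not interchangeable: with the rest of the structure unchanged, thiophen-2-yl and naphthalen-2-yl give numbers that differ beyond the scatter. The earlier compounds shown here could not show this, as they differ from one another in more than one place; the new pair shows that, of these two groups, thiophen-2-yl, with one five-membered aromatic ring and 5 heavy atoms, gives the lower number, while naphthalen-2-yl, with 2 six-membered aromatic rings and 10 heavy atoms, gives the higher.

On these data alone, with only these two groups compared at this position, it remains open whether a single phenyl ring or a furan-2-yl group on the same carbonyl carbon would stay close to compound 2 or move towards compound 4, and so whether the ring count, the atom count or the sulfur atom tracks the change. Nothing measured on these compounds beyond this read-out bears on why the number rises.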